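The compounds below may be only part of what the source reports. "The series", "measured", "known", "first", "only" and "open" are said of these compounds alone.

Compound 1 `CNc1nc(C)c(C(=O)N/N=C/c2cccc(C(F)(F)F)c2)s1` and compound 2 `CNc1nc(C(F)(F)F)c(C(=O)N/N=C/c2cccc(C(F)(F)F)c2)s1` share a core and were both tested in a functional assay on BCG823 cells (Homo sapiens) for inhibition, read by MTT assay, with a stated time of 72 h; a higher number here means a weaker inhibitor, a lower number a stronger inhibitor. In this assay compound 1 reaches only a limit, > 100 ug/mL. Compound 2 likewise reaches only a limit in this assay, > 100 ug/mL. The change between them, (trifluoromethyl in place of methyl on an aromatic carbon), therefore gives a step that the two limits leave unreadable from compound 1 to compound 2, because both values sit at the limit of > 100 ug/mL in this assay, at which 2 of the 3 values shown sit. Compound 3 `Cc1nc(N(C)C(=O)NC(=O)c2c(F)cccc2F)sc1C(=O)N/N=C/c1cc(C(F)(F)F)cc(C(F)(F)F)c1` gives 14.1 ug/mL in this assay; how its core differs from that of compound 1 is not broken down here. Compound 4 `CN(C(=O)NC(=O)c1c(F)cccc1F)c1nc(C(F)(F)F)c(C(=O)N/N=C/c2cc(C(F)(F)F)cc(C(F)(F)F)c2)s1` differs from compound 3 by trifluoromethyl in place of methyl on an aromatic carbon, the same kind of change as from compound 1 to compound 2, though here the ring atom next to the changed carbon bears a large group rather than a methylamino group. Since the measured step is unreadable, the expected step is a 1.0-fold lower number from compound 3 to compound 4 (0.00 log units; within the scatter), taken as small. Compound 4 is thus estimated at 14 ug/mL, between 5 ug/mL and 40 ug/mL.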

Compound 4, half-maximal inhibitory concentration: 5.28 ug/mL
Estimate against measurement, compound 4: 2.7-fold (0.42 log units) above; measured number inside the range.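

With the large group on the core, trifluoromethyl in place of methyl on an aromatic carbon gives, in this assay, a 2.7-fold lower number from compound 3 to compound 4 (0.43 log units; beyond the scatter). The same change on the core of compound 1 gives no readable step, because both of its compounds sit at a limit: the limit of > 100 ug/mL in this assay, at which 2 of the 4 values shown sit. The change is therefore sized on one core only, and the data do not show whether that size carries over from one core to another.

The compounds shown leave open how an ethyl group, a chlorine atom or an amine would behave on this aromatic carbon. They also leave open whether the step would hold if an acetyl group or a longer chain replaced the large group.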